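A few compounds are considered here, and "the series" means these few. Any claim that something is new, unique, unknown or untested is made for them only; others in the source may bear on it.

Measured so far in an ADME assay on Caco-2 cells (Homo sapiens) for permeability, read by LC-MS, with a stated time of 2 h; a higher number here means that the compound crosses the layer faster, a lower number that the compound crosses the layer more slowly: compound 1 `Cc1cc(CN(CC2CC2)C(CC(=O)O)c2ccc(Cl)cc2)ccc1OCCn1c(=O)ccn(C)c1=O` gives 3.7 nm/s; compound 2 `COc1cc(CN(CC2CC2)C(CC(=O)O)c2ccc(Cl)cc2)ccc1OCCn1c(=O)ccn(C)c1=O` gives 0.8 nm/s; compound 3 `COc1cc(CN(CC(C)C)C(CC(=O)O)c2ccc(Cl)c(F)c2)ccc1OCCN1C(=O)CCC1=O` gives 5.88 nm/s.

Within the first pair, the change methyl in place of methoxy on an aromatic carbon made the step of a 4.6-fold higher number from compound 2 to compound 1 (0.67 log units; beyond the scatter). How the core of compound 2 differs from the core of compound 3 is not broken down here. Compound 4 `Cc1cc(CN(CC(C)C)C(CC(=O)O)c2ccc(Cl)c(F)c2)ccc1OCCN1C(=O)CCC1=O` differs from compound 3 by methyl in place of methoxy on an aromatic carbon, the same kind of change; around the place it sits ortho to a 2-(2,5-dioxopyrrolidin-1-yl)ethoxy group in compound 3, where in compound 2 the place was ortho to a large group. Resting on the one earlier step of a 4.6-fold higher number from compound 2 to compound 1 (0.67 log units; beyond the scatter), a step of similar size, a 3.4-fold higher number from compound 3 to compound 4 (0.53 log units; beyond the scatter), is expected in this assay. Compound 4 is therefore estimated at 20 nm/s, between 7 nm/s and 50 nm/s.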

Compound 4, apparent permeability: 37.8 nm/s
Compound 4: middle estimate off by 1.9-fold (0.28 log units), on the low side, and the stated range covers the measured number.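

In this assay, putting methyl in place of methoxy on an aromatic carbon on the second core gave a 6.4-fold higher number from compound 3 to compound 4 (0.81 log units; beyond the scatter). Set beside the earlier step, the two results agree: the same change on two cores in this assay, a 4.6-fold higher number (0.67 log units; beyond the scatter) from compound 2 to compound 1 and a 6.4-fold higher number (0.81 log units; beyond the scatter) from compound 3 to compound 4, 1.4-fold (0.14 log units) apart, within the scatter of two such steps. This shows that the change carried over between these two cores, but two cores cannot show that it would hold on any other core, and the steps alone do not say what in the change produces them.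

The compounds shown leave open whether an ethyl group, a chlorine atom or a plain hydrogen at the same place would give a step of similar size. They also leave open whether the step would survive replacing the carboxylic acid with a primary amide.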